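Adding a Propyl Group to Compound 1

The source may report more compounds than this note shows. Statements on the series, on what has been measured and on what is new or still open speak of the compounds shown alone.

Compound 1 `Cc1ccc(NC(=O)N[C@H](C)c2ccccc2)cc1` is one of three ureas measured so far. In an ADME assay on the whole organism with Oryza sativa as the target, tested at 0.1 uM (a higher number here means a weaker effect of the compound at the concentration tested, a lower number a stronger effect), compound 1 gives 100%. Its mirror image, compound 2 `Cc1ccc(NC(=O)N[C@@H](C)c2ccccc2)cc1`, gives 100% in the same assay, and compound 3 `CCc1ccccc1NC(=O)N[C@@H](C)c1ccccc1` gives 100%. Among the measured compounds shown here, the only step measured between neighbours is the one from compound 1 to compound 2, no change at the digits printed from compound 1 to compound 2 (within the scatter), a pair that differ in nothing but configuration (the fact that compounds 1 and 2 differ only in the configuration as drawn). Compound 1 therefore stands level with compounds 2 and 3 at the digits shown, and no compound in the set has moved away from the others.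

The next compound, compound 4 `CCCCc1ccc(NC(=O)N[C@H](C)c2ccccc2)cc1`, differs from compound 1 by propyl in place of hydrogen on a saturated chain carbon bound to an aromatic carbon. For the measured compounds named here, no measured step resembles this change: the one step known concerns configuration alone, and compound 3 against compound 1 shows only two equal values. What the data offer is a flat set, with every compound at the same reading, and nothing that points in either direction. On that basis the step in this assay is expected to stay within the scatter. The expected step is no change at the digits printed from compound 1 to compound 4 (within the scatter). Compound 4 is thus estimated to give 100%, with a range from 88% to 100%.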

Compound 4, a percentage reported as activity, at one concentration (the size of the read-out at that concentration, not a potency): 100%
The estimate for compound 4 equals the measured number at the digits printed; measured number inside the range.
By their numbers in this assay, from the lowest: compounds 1, 2, 3 and 4 (each within the scatter of the next).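

With propyl in place of hydrogen on a saturated chain carbon bound to an aromatic carbon, a change that reads methyl to butyl when cut one bond further out, this assay shows no change at the digits printed from compound 1 to compound 4 (within the scatter). Among the compounds shown here, this is the first step in the set that alters the atoms of compound 1 rather than its configuration alone, and it shows that this place can carry a further 3 heavy atoms, all carbon, with the reading still level with the other compounds at the single concentration tested. Nothing known about these compounds bears on why the reading holds across this change.

What the compounds shown leave open is whether any group at this place can move the reading in this assay at all, since all four stand level and a flat set gives no direction for a stronger or a weaker effect. An amine or a carboxylic acid at the end of the chain, or a longer chain such as octyl, might read differently from compound 4, and nothing here can say whether it would.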